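The source may report more compounds than this note shows. Statements on the series, on what has been measured and on what is new or still open speak of the compounds shown alone.

Of the compounds shown here, three of a shared core have been tested in a functional assay on SK-MEL-5 cells (Homo sapiens) for cytotoxicity, read by sulforhodamine B assay, with a stated time of 48 h; on this read-out lower numbers stand for higher toxicity in this test and higher numbers for lower toxicity in this test. Compound 1 `ClCc1cccc(Cn2cnc3ncnc(Cl)c32)c1` gives 45700 nM in this assay. Compound 2 `ClCc1ccc(Cn2cnc3nc(Cl)nc(Cl)c32)cc1`, which carries a second chloro group on the core, gives 31600 nM in this assay. Compound 3 `Nc1nc(Cl)c2ncn(Cc3cccc(CCl)c3)c2n1`, with an amino group in place of that second chloro, gives 51300 nM in this assay. All three numbers sit within the scatter of one another, so compound 2 cannot be set apart from compound 1 or compound 3 on these data; the whole set lies in a weakly toxic range.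

Compound 4 `ClCc1ccc(Cn2cnc3ncnc(Cl)c32)cc1` has not yet been measured. Going from compound 2 to compound 4 the change is hydrogen in place of chloro on an aromatic carbon. Compound 2 and compound 1 share this hydrogen-versus-chloro difference at that spot, differing also in where the chloromethyl group sits on the benzyl ring, and their numbers lie within the scatter. Among the compounds with values here, no pair differing only in this one place has been measured, so no step size can be read off directly.

The expectation is therefore a step of a 1.3-fold higher number from compound 2 to compound 4 (0.10 log units; within the scatter) that stays within the scatter, with no clear direction. Compound 4 is expected to give about 40000 nM in this assay, plausibly between 15000 nM and 100000 nM.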

Compound 4, concentration lethal to 50% of the cells: 34700 nM
Compound 4: the middle estimate sits 1.2-fold (0.06 log units) above what was measured; low and high end bracket the measured number.
By their numbers in this assay, from the lowest: compounds 2, 4, 1 and 3 (each within the scatter of the next).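

In this assay, putting hydrogen in place of chloro on the aromatic carbon between two ring nitrogen atoms gives a 1.1-fold higher number from compound 2 to compound 4 (0.04 log units; within the scatter). Within the data shown here, this is the first pair that differs in this one place alone, whereas the earlier comparison of compound 2 with compound 1 also involved a shift of the chloromethyl group on the benzyl ring. With that group held in place, the chloro at this position can therefore be removed without a change that this test can tell apart from ordinary scatter, and no further measurement bears on why the step is so small.

Still open, on these data alone, is whether a larger or very different group at this position, such as a methoxy group or a carboxylic acid, would move the number beyond the scatter, since this one pair covers only chloro and hydrogen. The compounds shown also all carry the chloromethyl group and the chloro on the core, so they leave unanswered what would happen if the chloromethyl group gave way to a plain methyl group.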